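A side-chain swap at the assay limit

The compounds below may be only part of what the source reports. "The series", "measured", "known", "first", "only" and "open" are said of these compounds alone.

In a functional assay on A549 cells (Homo sapiens) for antiproliferative activity, read by MTT assay, with a stated time of 48 h (on this read-out lower numbers stand for stronger inhibition and higher numbers for weaker inhibition), compound 3 `CN1CCN(CCCn2nc(C3=C(c4cn(C)c5ccccc45)C(=O)NC3=O)c3cccnc32)CC1` gives > 100000 nM, which is a limit and not a number. Compound 1 `Cn1cc(C2=C(c3nn(CCCn4cncn4)c4ncccc34)C(=O)NC2=O)c2ccccc21` gives > 100000 nM, also a limit. Compound 2 `Cn1cc(C2=C(c3nn(CCCn4cncn4)c4ncccc34)C(=O)N(c3ccccc3)C2=O)c2ccccc21` gives > 100000 nM, again a limit. For the measured compounds named here, the record so far is thus (the limit of > 100000 nM in this assay, at which 3 of the 3 values shown sit), and no compound has yet given a true number.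

Compound 4 `Cn1cc(C2=C(c3nn(CCCCn4ccnc4)c4ncccc34)C(=O)NC2=O)c2ccccc21` changes the end of the side chain of compound 3: (1H-imidazol-1-yl)methyl in place of 4-methylpiperazin-1-yl on a saturated chain carbon, three bonds along the chain from an aromatic nitrogen. In words, this is (1H-imidazol-1-yl)methyl in place of 4-methylpiperazin-1-yl on a saturated chain carbon, three bonds along the chain from an aromatic nitrogen.

The closest guide is a step that the two limits leave unreadable from compound 1 to compound 3 at the same chain end, and the other is a step that the two limits leave unreadable from compound 1 to compound 2 on the amide-type nitrogen. Neither has a readable size, so no shift in either direction can be predicted. The expected change is a number no higher from compound 3 to compound 4 (the limit leaves the size open), with nothing expected beyond the scatter. Compound 4 is estimated at 100000 nM, with an expected range of 30000 nM to 300000 nM, and will most likely be reported as a limit again.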

Compound 4, half-maximal inhibitory concentration: 2380 nM
The estimate for compound 4 lay 42-fold (1.62 log units) above the measured number; the measured number lies below the stated range.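

The end of this side chain clearly matters in this assay: (1H-imidazol-1-yl)methyl in place of 4-methylpiperazin-1-yl gives an at least 42-fold lower number from compound 3 to compound 4 (1.62 log units; beyond the scatter), and the same group in place of 1H-1,2,4-triazol-1-yl gives an at least 42-fold lower number from compound 1 to compound 4 (1.62 log units; beyond the scatter). Each of these sizes is a minimum and not an exact figure, yet both lie beyond the scatter. Compound 4 is the only compound here with a true number, and the others remain at the assay limit: the limit of > 100000 nM in this assay, at which 3 of the 4 values shown sit.

The steps among compounds 1, 2 and 3 cannot be read, so nothing is known about how the phenyl on the amide-type nitrogen acts when the side chain ends in imidazole. On these data alone, it also remains open whether the gain follows the imidazole ring or the longer chain, a question that a 3-(1H-imidazol-1-yl)propyl chain on the same core would address.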